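The compounds below may be only part of what the source reports. "The series", "measured", "known", "first", "only" and "open" are said of these compounds alone.

Working notes on a shared core tested in a functional assay on PC-3 cells (Homo sapiens) for antiproliferative activity, read by MTT assay, with a stated time of 48 h; a higher number here means a weaker inhibitor, a lower number a stronger inhibitor. Compound 2 `Cc1cccc(C(=O)Nc2cc(Sc3ncn[nH]3)c(O)c3ccccc23)c1` gives 59500 nM, the lowest of the two numbers obtained so far; compound 3 `O=C(Nc1cc(Sc2ncnc3nc[nH]c23)c(O)c2ccccc12)c1ccc(Cl)cc1` gives 66400 nM, which sits within the scatter of compound 2. Compound 1 `O=C(Nc1cc(Sc2ncnc3nc[nH]c23)c(O)c2ccccc12)c1ccc([N+](=O)[O-])cc1` reaches only the limit > 100000 nM, and the limit of > 100000 nM in this assay, at which 1 of the 3 values shown sits, is all that is known of it. Among the measured compounds shown here, the sole one-place step measured, an at least 1.5-fold lower number from compound 1 to compound 3 (0.17 log units; that floor lies within the scatter), concerns an exchange on an aromatic carbon and not the group on the carbonyl carbon, so it does not bear on the change considered here. Compound 4 `O=C(/C=C/c1ccccc1)Nc1cc(Sc2ncn[nH]2)c(O)c2ccccc12` differs from compound 2 by 2-phenylethenyl in place of 3-methylphenyl on a carbonyl carbon. For the measured compounds named here, with no measured step bearing on it, no movement beyond the scatter is expected in this assay. Compound 4 is therefore estimated at 55000 nM, with a range from 20000 nM to 150000 nM. The step of a 1.1-fold lower number from compound 2 to compound 4 (0.03 log units; within the scatter) is expected to stay within the scatter.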

Compound 4, half-maximal inhibitory concentration: > 100000 nM
Compound 4: no number, only a limit; the forecaster's own chance of this, stated with the estimate: 25%; middle value at least 1.8-fold (0.25 log units) from the limit.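

Among the compounds shown here, at the group on the carbonyl carbon, the first measured exchange in this assay is an at least 1.6-fold higher number from compound 2 to compound 4 (0.22 log units; that floor lies within the scatter). Going by these compounds, its floor does not clear the scatter, so a real loss on going from 3-methylphenyl to 2-phenylethenyl is possible but not established, and its size is unknown. Compound 4 gives only a limit of the assay, as compound 1 does: the limit of > 100000 nM in this assay, at which 2 of the 4 values shown sit.

On these data alone, whether a 2-phenylethyl chain, without the double bond, would read as compound 2 or as compound 4 stays open. So does the effect of an amine or carboxylic acid carried on that carbonyl carbon.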